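Arginine to Lysine Side Chain on a Purine Core

The source may report more compounds than this note shows. Statements on the series, on what has been measured and on what is new or still open speak of the compounds shown alone.

The measured compounds are compound 1 `N=C(N)NCCC[C@H](NC(=O)CN(c1nc(Cl)nc2[nH]cnc12)C1CC1)C(=O)O`, compound 2 `C[C@@H](O)[C@H](NC(=O)CN(c1ncnc2c1ncn2C1CCCCO1)C1CC1)C(=O)OCc1ccccc1` and compound 3 `C[C@H](NC(=O)CN(c1ncnc2c1ncn2C1CCCCO1)C1CC1)C(=O)OCc1ccccc1`. In a functional assay on the whole organism (Tail, strain ICR) with Mus musculus as the target, in the tail flick test, with a stated time of 60 min, at a dose of 25 umol/kg by the oral route (on this read-out higher numbers stand for a stronger effect at the one dose given and lower numbers for a weaker effect), compound 1 gives 51%, compound 2 gives 28.4% and compound 3 gives 53%.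

Compound 1 stands second highest of the three numbers; its value and that of compound 3 lie within the scatter of each other, while compound 2 lies well below it. For the measured compounds named here, the only step with one change among the measured compounds, a number 24.6 percentage points higher from compound 2 to compound 3 (beyond the scatter), concerns the side chain on the carbon bound to the amide-type nitrogen, a different position from the one altered in compound 4.

Compound 4 `NCCCC[C@H](NC(=O)CN(c1nc(Cl)nc2[nH]cnc12)C1CC1)C(=O)O` differs from compound 1 by a group of 2 heavy atoms (1 carbon, 1 nitrogen; no ring) in place of a group of 4 heavy atoms (1 carbon, 3 nitrogen; no ring), on a saturated chain carbon, four bonds along the chain from an amide-type nitrogen and a carbonyl carbon. Going by the values given here, no measured step bears on this exchange, so the expectation rests on compound 1 alone. A step of a number 6 percentage points lower from compound 1 to compound 4 (within the scatter) is expected, that is, no step beyond the scatter. Compound 4 is therefore estimated at 45%, with a range from 20% to 70%.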

Compound 4, a percentage reported as activity, at one dose (the size of the read-out at that dose, not a potency): 53.8%
Compound 4: middle estimate off by 8.8 percentage points, on the low side; the measured number falls inside the stated range.
By their numbers in this assay, from the lowest: compound 2; then compounds 1, 3 and 4 (each within the scatter of the next).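

In this assay, the exchange gives a number 2.8 percentage points higher from compound 1 to compound 4 (within the scatter), so the aminomethyl group and the group of 4 heavy atoms it replaces cannot be told apart on this read-out at the one dose given. For the compounds shown here, the earlier step spoke only to the side chain on the saturated chain carbon bound to an amide-type nitrogen and a carbonyl carbon, whereas this pair gives the first reading for a change four bonds along the chain, and that change leaves the two compounds within the scatter of each other. Nothing measured here accounts for this result.

On these data alone, it remains open whether a carboxylic acid or a hydroxyl group in this place would also stay within the scatter of compound 1. A reading at one dose also leaves open whether compound 1 and compound 4 would still match at other doses.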